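Swapping the amine linker for an ether

This account rests on a few compounds, and the source may have more. Where it says the series, first, only, none or still open, it means among the compounds named here.

Compound 1 `CC(C)c1onc(-c2c(Cl)cccc2Cl)c1COc1ccc(NCc2ccc(C(=O)O)cc2)c(C(F)(F)F)n1` gives 398 nM in a functional assay on HEK293 cells for agonist activity at Bile acid receptor (Homo sapiens); a higher number here means that more compound is needed for the effect, a lower number that less compound is needed. Compound 2 `CC(Nc1ccc(C(=O)O)cc1)c1ccc(OCc2c(-c3c(Cl)cccc3Cl)noc2C2CC2)nc1C(F)(F)F` gives 333 nM in this assay, the lower of the two numbers, though its gap to compound 1 lies within the scatter. Compound 3 `CC(Oc1ccc(C(=O)O)cc1)c1ccc(OCc2c(-c3c(Cl)cccc3Cl)noc2C2CC2)nc1C(F)(F)F` carries 4-carboxyphenoxy in place of (4-carboxyphenyl)amino on a saturated chain carbon bound to an aromatic carbon and a saturated chain carbon, that is, 4-carboxyphenoxy in place of (4-carboxyphenyl)amino on a saturated chain carbon bound to an aromatic carbon and a saturated chain carbon. Among the measured compounds shown here, no measured pair shows this change, so the expected step of a 1.8-fold higher number from compound 2 to compound 3 (0.26 log units; within the scatter) is a modest rise, perhaps not beyond the scatter. Compound 3 is expected to give 600 nM in this assay, within a range of 200 nM to 2000 nM.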

Compound 3, half-maximal effective concentration: 189 nM
Compound 3: the middle estimate sits 3.2-fold (0.50 log units) above what was measured; the measured number lies below the stated range.
By their numbers in this assay, from the lowest: compounds 3, 2 and 1 (each within the scatter of the next, the first and the last beyond it).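

Among the compounds shown here, this pair gives the first step that differs in one place. On a saturated chain carbon bound to an aromatic carbon and a saturated chain carbon, 4-carboxyphenoxy can stand in place of (4-carboxyphenyl)amino in this assay with no change beyond the scatter (a 1.8-fold lower number from compound 2 to compound 3 (0.25 log units; within the scatter)), so the nitrogen of this link is not needed for activity here. Nothing at hand explains why the two groups read alike. The compounds shown leave open whether a thioether or a methylene link would also hold up at this place.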